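The compounds below may be only part of what the source reports. "The series", "measured", "known", "first", "only" and "open" are said of these compounds alone.

Compound 1 `CCOC(=O)C1=C(Nc2ccc(OC)cc2)S/C(=C\c2ccc[nH]2)C1=O`: < 10%
Compound 2 `CCOC(=O)C1=C(Nc2ccc(F)cc2)S/C(=C\c2ccc[nH]2)C1=O`: < 10%

In a functional assay on MCF7 cells (Homo sapiens) for inhibition, read by MTT assay, with a stated time of 72 h, tested at 10 uM (on this read-out lower numbers stand for less inhibition and higher numbers for more inhibition at the one concentration tested (going by the name of the read-out)), compound 2 gives < 10%, which is a limit of the assay rather than a number. Compound 1 in this assay gives < 10%, likewise only a limit. Among the measured compounds shown here, the single measured step, a step that the two limits leave unreadable from compound 1 to compound 2, cannot be read because both values sit at the limit of < 10% in this assay, at which 2 of the 2 values shown sit. Compound 3 `CCOC(=O)C1=C(Nc2cccc(F)c2)S/C(=C\c2ccc[nH]2)C1=O` differs from compound 2 by 3-fluorophenyl in place of 4-fluorophenyl on an amine nitrogen. For the measured compounds named here, no measured step bears on this change, so no shift beyond the scatter is expected in this assay. Compound 3 is therefore expected to give about 5%, within 0% to 15%. The expected step is thus a step that the limit leaves unreadable from compound 2 to compound 3.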

Compound 3, a percentage reported as inhibition, at one concentration (the size of the read-out at that concentration, not a potency): < 10%
Compound 3 ended at the assay's limit; the forecaster's own chance of this, stated with the estimate: 85%; the middle value is on the limit's open side.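

Among the compounds shown here, no step among compound 1, compound 2 and compound 3 can be read, because in this assay all three sit at a limit of the assay, not at a number: the limit of < 10% in this assay, at which 3 of the 3 values shown sit. Going by these compounds, whether 4-methoxyphenyl, 4-fluorophenyl or 3-fluorophenyl on the amine nitrogen makes any difference to inhibition stays open.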